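Working notes: a larger side chain on compound 2

The source may hold more compounds than are shown below. What is called first, only, known or untested is meant among the compounds shown, and "the series" means these compounds.

Measured in a functional assay on A549 cells (Homo sapiens) for inhibition, read by MTT assay, with a stated time of 48 h; a lower number here means a stronger inhibitor, a higher number a weaker inhibitor:
compound 1 `C[Se]c1ccc(N(C)c2nc(C)nc3ccccc23)cc1C` gives 2 nM
compound 2 `COc1ccc(N(C)c2nc(C)nc3ccccc23)cc1` gives 3 nM

Compound 2 has the highest of the two numbers, but the nearest number, that of compound 1, differs by less than the scatter, so the two compounds are treated as equal here. Within the data shown here, no step between measured compounds is available.

Compound 3 `COc1ccc(N(C)c2nc(C)nc3ccccc23)cc1OCCC[Se]C#N` differs from compound 2 by a group of 7 heavy atoms (4 carbon, 1 nitrogen, 1 oxygen, 1 selenium; no ring) in place of a hydrogen atom, on an aromatic carbon. The entering group has no ring and carries a triple bond outside aromatic rings; it sits on an aromatic carbon ortho to a methoxy group and meta to a large group.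

Among the measured compounds shown here, no measured step supports this change; the two numbers only show that both compounds lie in the low range of this assay. The expected step of a 3.3-fold higher number from compound 2 to compound 3 (0.52 log units; beyond the scatter) in this assay is toward a weaker inhibitor, of a size that may just exceed the scatter. Compound 3 is estimated at 10 nM, with a range of 2 nM to 50 nM.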

Compound 3, half-maximal inhibitory concentration: 382 nM
The estimate for compound 3 lay 38-fold (1.58 log units) below the measured number, and the stated range ends below it.
By their numbers in this assay, from the lowest: compounds 1 and 2 (each within the scatter of the next); then compound 3.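

The position on the aromatic carbon ortho to a methoxy group and meta to a large group does not take this change freely: in this assay the change gives a 130-fold higher number from compound 2 to compound 3 (2.10 log units; beyond the scatter) and so marks a large move toward a weaker inhibitor. Compound 3 still gives a measured number of 382 nM in this assay, so the open-chain group with its triple bond lowers inhibition at this position without removing it. No available data bear on the reason for this step.

With a single group at this position, the effect of the chain cannot be separated from that of the selenium and nitrile at its end. A plain ethoxy group, a shorter chain, or the same chain ending in an amine or a carboxylic acid would each test one of these parts.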